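Shortening the chain and swapping the sulfur linker for an amine

A few compounds are considered here, and "the series" means these few. Any claim that something is new, unique, unknown or untested is made for them only; others in the source may bear on it.

Of the compounds shown here, three built on one shared core have been tested in a functional assay (Pituitary gland cell) with Rattus norvegicus as the target; on this read-out lower numbers stand for an effect already at smaller amounts and higher numbers for an effect only at larger amounts of compound. Compound 1 `CC(C)(N)CCCSC1CCc2ccccc2N(Cc2ccc(-c3ccccc3-c3nn[nH]n3)cc2)C1=O` gives 7 uM, and compound 2 `CC(C)(N)CCSC1CCc2ccccc2N(Cc2ccc(-c3ccccc3-c3nn[nH]n3)cc2)C1=O` gives 6 uM. Compound 3 `CC(C)(N)CNC(=O)N[C@@H]1CCc2ccccc2N(Cc2ccc(-c3ccccc3-c3nn[nH]n3)cc2)C1=O` gives 0.1 uM. Among these three numbers compound 2 stands second highest; its nearest neighbour is compound 1, while compound 3 lies furthest away from it with a markedly lower number.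

Going by the values given here, the one single-point step that has been measured is a 1.2-fold lower number from compound 1 to compound 2 (0.07 log units; within the scatter), which shows that trimming the chain by one carbon on its way to the terminal amine made no difference beyond the scatter.

Compound 4 `CC(C)(N)CNC1CCc2ccccc2N(Cc2ccc(-c3ccccc3-c3nn[nH]n3)cc2)C1=O` has not been measured. It differs from compound 2 in that ((2-amino-2-methylpropyl)amino in place of (3-amino-3-methylbutyl)sulfanyl on a saturated ring carbon). Among the compounds with values here, no measured step covers an exchange of a sulfur linker for an amine linker; the only guidance is that compound 2 gives 6 uM while compound 3, which also carries a nitrogen-linked 2-amino-2-methylpropyl group, gives 0.1 uM. On that basis compound 4 is expected to fall between the two, and the estimated step is a 3.0-fold lower number from compound 2 to compound 4 (0.48 log units; beyond the scatter). Compound 4 is therefore estimated at 2 uM, within a range from 0.4 uM to 10 uM.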

Compound 4, concentration for half-maximal effect: 1 uM
For compound 4 the middle estimate is 2.0-fold (0.30 log units) above the measured one; low and high end bracket the measured number.
By their numbers in this assay, from the lowest: compound 3; then compound 4; then compounds 2 and 1 (each within the scatter of the next).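

In this assay, the swap at the saturated ring carbon of the seven-membered ring gives a 6.0-fold lower number from compound 2 to compound 4 (0.78 log units; beyond the scatter) and so, unlike the trimming of the sulfur-linked chain, moves the number beyond the scatter. Measured against the longer sulfur-linked chain, the same position gives a 7.0-fold lower number from compound 1 to compound 4 (0.85 log units; beyond the scatter) and points the same way, so with (2-amino-2-methylpropyl)amino on this carbon, compound 4 stands apart from both sulfur-linked compounds on the lower side. No available evidence bears on why this exchange lowers the number.

The entering group differs from the leaving one both in the linking atom, nitrogen for sulfur, and in the chain, so these compounds do not show how much of the step belongs to each, and the near-equal values of the two sulfur-linked compounds speak only for chains attached through sulfur. A (3-amino-3-methylbutyl)amino group on the same carbon would separate the two changes, and an ether oxygen as the linking atom remains an open question as well.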